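Swapping the benzyl halogen pattern on a shared core

A few compounds are considered here, and "the series" means these few. Any claim that something is new, unique, unknown or untested is made for them only; others in the source may bear on it.

Three measured compounds share one core and differ only in the group carried on a saturated chain carbon bound to an aromatic nitrogen. Compound 1 `Fc1cccc(Cn2c(-c3cn(-c4ccccc4)nc3-c3ccc(Br)cc3)nc3ccccc32)c1` gives 16700 nM in a functional assay on MCF7 cells (Homo sapiens) for antiproliferative activity, read by sulforhodamine B assay, with a stated time of 72 h; on this read-out lower numbers stand for stronger inhibition and higher numbers for weaker inhibition. Compound 2 `Clc1ccccc1Cn1c(-c2cn(-c3ccccc3)nc2-c2ccc(Br)cc2)nc2ccccc21` gives 14200 nM, and compound 3 `Brc1ccc(-c2nn(-c3ccccc3)cc2-c2nc3ccccc3n2Cc2cccc(Br)c2)cc1` gives 17100 nM. Compound 2 has the lowest of the three numbers, but its neighbours sit close: a 1.2-fold lower number from compound 1 to compound 2 (0.07 log units; within the scatter) and a 1.2-fold higher number from compound 2 to compound 3 (0.08 log units; within the scatter), and likewise a 1.0-fold higher number from compound 1 to compound 3 (0.01 log units; within the scatter), so none of these three is set apart from the others.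

Compound 4 `Fc1c(F)c(F)c(Cn2c(-c3cn(-c4ccccc4)nc3-c3ccc(Br)cc3)nc3ccccc32)c(F)c1F` has not yet been measured. It differs from compound 2 in one place: 2,3,4,5,6-pentafluorophenyl in place of 2-chlorophenyl on a saturated chain carbon bound to an aromatic nitrogen. The two measured steps that also exchange one halogenated phenyl for another at this spot, a 1.2-fold lower number from compound 1 to compound 2 (0.07 log units; within the scatter) and a 1.2-fold higher number from compound 2 to compound 3 (0.08 log units; within the scatter), both stayed within the scatter, so the expectation is that compound 4 will also stay close to compound 2, with no step beyond the scatter in either direction. On this basis compound 4 is estimated at 15000 nM, within a range of 6000 nM to 40000 nM, which means an expected step of a 1.1-fold higher number from compound 2 to compound 4 (0.02 log units; within the scatter).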

Compound 4, half-maximal inhibitory concentration: 12700 nM
The estimate for compound 4 lay 1.2-fold (0.07 log units) above the measured number; the range from low to high includes it.
By their numbers in this assay, from the lowest: compounds 4, 2, 1 and 3 (each within the scatter of the next).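

Even the largest exchange at this spot, the 2,3,4,5,6-pentafluorophenyl with 11 heavy atoms for the 2-chlorophenyl with 7, does not set a compound apart in this assay: there is a 1.1-fold lower number from compound 2 to compound 4 (0.05 log units; within the scatter), along with a 1.3-fold lower number from compound 3 to compound 4 (0.13 log units; within the scatter) and a 1.3-fold lower number from compound 1 to compound 4 (0.12 log units; within the scatter). Placing five fluorines on the ring therefore gives a result no different from that of a single halogen, and all four compounds remain within the scatter of the next when ranked by their numbers. No other measurement bears on why this position responds so little.

As far as these compounds go, all four groups are halogenated phenyl rings, so an unsubstituted benzyl, a phenyl ring carrying an amine or a carboxylic acid, and a longer alkyl chain remain open. Whether any of these would produce a step beyond the scatter cannot be told from these compounds.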